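The compounds below may be only part of what the source reports. "The series", "measured", "known", "first", "only" and "open" are said of these compounds alone.

The study concerns four compounds that share a bicyclic core bearing an arylsulfonamide, and it asks how one substituent on the ring nitrogen of that core affects growth inhibition. Compound 1 `COc1ncc(-c2ccc3c(c2)N(c2ccccc2)C(=O)CO3)cc1NS(=O)(=O)c1ccc(F)cc1` carries a phenyl on an amide-type nitrogen in a ring, and in a functional assay on HepG2 cells (Homo sapiens) for antiproliferative activity, read by MTT assay, with a stated time of 72 h (on this read-out lower numbers stand for stronger inhibition and higher numbers for weaker inhibition), compound 1 gives 14000 nM. Compound 3 `COc1ncc(-c2ccc3c(c2)N(C2CC2)C(=O)CO3)cc1NS(=O)(=O)c1ccc(F)cc1` is its counterpart in which the change cyclopropyl in place of phenyl on an amide-type nitrogen in a ring has been made. In this assay compound 3 gives 14400 nM, so that the step of a 1.0-fold higher number from compound 1 to compound 3 (0.01 log units; within the scatter) leaves the read-out essentially unchanged.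

Compound 2 `O=C1COc2ccc(-c3cccc(NS(=O)(=O)c4ccc(F)cc4)c3)cc2N1c1ccccc1` belongs to a second core: the difference between the two cores is not broken down here. In this assay compound 2 gives 30300 nM, the highest number of the three measured compounds, beyond the scatter from both compound 1 and compound 3.

Compound 4 `O=C1COc2ccc(-c3cccc(NS(=O)(=O)c4ccc(F)cc4)c3)cc2N1C1CC1` has not been measured. It stands to compound 2 as compound 3 stands to compound 1, through the same change (cyclopropyl in place of phenyl on an amide-type nitrogen in a ring), at a place described in identical terms for both pairs. Within the data shown here, since the only measured instance of this change, from compound 1 to compound 3, produced a 1.0-fold higher number from compound 1 to compound 3 (0.01 log units; within the scatter), compound 4 is expected to land close to compound 2, with an estimated step of a 1.0-fold lower number from compound 2 to compound 4 (0.00 log units; within the scatter). The estimate for compound 4 in this assay is therefore 30000 nM, expected to fall between 14000 nM and 65000 nM; this rests on a single precedent, and the second core may not answer the change in the same way.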

Compound 4, half-maximal inhibitory concentration: > 40000 nM
Compound 4: a limit, no number; the forecaster's own chance of this, stated with the estimate: 15%; middle value at least 1.3-fold (0.12 log units) from the limit.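

In this assay compound 4 gives > 40000 nM, which is a limit of the assay and not a number. On the core of compound 2, cyclopropyl in place of phenyl on an amide-type nitrogen in a ring therefore gives an at least 1.3-fold higher number from compound 2 to compound 4 (0.12 log units; that floor lies within the scatter), so this step is known only by its floor and has no measured size. This is compatible with the change carrying over to the second core much as it did on the first, and equally with a larger step there, so the result neither shows that the change transfers nor shows that it does not, and the one value sitting at the limit is what keeps the comparison incomplete: the same change on two cores in this assay, a 1.0-fold higher number (0.01 log units; within the scatter) from compound 1 to compound 3 and an at least 1.3-fold higher number (0.12 log units; that floor lies within the scatter) from compound 2 to compound 4; the limit leaves it open whether they differ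

The compounds shown leave open how a methyl, a benzyl or a longer chain on that ring nitrogen would read on either core, and whether a chain ending in an amine or a carboxylic acid would depart from the phenyl and cyclopropyl results. They also leave open how the same change would behave on any third core, since the comparison rests on just these two pairs.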